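Chloro Substitution on a Dithiocarbamate Chromone Scaffold

A few compounds are considered here, and "the series" means these few. Any claim that something is new, unique, unknown or untested is made for them only; others in the source may bear on it.

Two dithiocarbamates were measured in a functional assay on HEp-2 cells (Homo sapiens) for antiproliferative activity, read by MTT assay, with a stated time of 72 h; a lower number here means a stronger inhibitor, a higher number a weaker inhibitor. Compound 1 `O=c1c(CSC(=S)N2CCCC2)coc2cc(Cl)ccc12` carries a chloro group and a pyrrolidine dithiocarbamate; in this assay compound 1 gives 2100 nM. Compound 2 `CC(C)N(C(=S)SCc1coc2ccccc2c1=O)C(C)C` carries a diisopropyl dithiocarbamate and no chloro group; in this assay compound 2 gives 3000 nM. Compound 2 has the higher of the two numbers, and its nearest neighbour is compound 1, whose number is lower by an amount within the usual scatter, so the two cannot be ranked against each other.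

Compound 3 `CC(C)N(C(=S)SCc1coc2cc(Cl)ccc2c1=O)C(C)C` differs from compound 2 by a single change: chloro in place of hydrogen on an aromatic carbon. Going by the values given here, no measured pair in this set isolates this exchange, so there is no directly observed step to lean on. The comparison of compound 1 and compound 2, which differ in two places at once, shows only that both lie within the scatter of each other. Hence a step of no size beyond the scatter is expected from compound 2 to compound 3, with a 1.2-fold lower number from compound 2 to compound 3 (0.08 log units; within the scatter) as the estimate. Compound 3 is therefore expected to give about 2500 nM in this assay, most likely between 1000 nM and 6500 nM.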

Compound 3, half-maximal inhibitory concentration: 4200 nM
Estimate against measurement, compound 3: 1.7-fold (0.23 log units) below; the measured number falls inside the stated range.
By their numbers in this assay, from the lowest: compounds 1, 2 and 3 (each within the scatter of the next).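

In this assay the exchange of hydrogen for chloro on an aromatic carbon, meta to a fused ring and para to a fused ring, can now be read on its own with the diisopropyl dithiocarbamate held fixed, and it gives a 1.4-fold higher number from compound 2 to compound 3 (0.15 log units; within the scatter) and so stays inside the scatter. With the chloro group held fixed, diisopropylamino in place of pyrrolidin-1-yl on the thiocarbonyl carbon gives a 2.0-fold higher number from compound 1 to compound 3 (0.30 log units; within the scatter) and also stays inside the scatter, so neither single change separates the compounds it connects in this assay. The data offer nothing that would explain these results.

The compounds shown leave open whether a fluoro, bromo or methoxy group on this aromatic carbon would give a step beyond the scatter, and whether chloro would behave the same way with the pyrrolidin-1-yl group in place. They also leave open whether a morpholin-4-yl, piperidin-1-yl or dimethylamino group on the thiocarbonyl carbon would separate from the two amines seen here.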